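A few compounds are considered here, and "the series" means these few. Any claim that something is new, unique, unknown or untested is made for them only; others in the source may bear on it.

Series notes. Compound 1 `CCN(CC)c1ccc2cc(C(=O)c3ccc(N4CCN(C(=O)CN5CCN(S(=O)(=O)c6ccc(C(F)(F)F)cc6)CC5)CC4)cc3)oc2c1` carries a (4-(trifluoromethyl)phenyl)sulfonyl group on the piperazine. In a functional assay on HeLa cells (Homo sapiens) for cytotoxicity, read by MTT assay, with a stated time of 48 h (a higher number here means a weaker inhibitor, a lower number a stronger inhibitor), compound 1 gives only a limit, > 40000 nM. Compound 2 `CCN(CC)c1ccc2cc(C(=O)c3ccc(N4CCN(C(=O)CN5CCN(S(=O)(=O)c6ccc(C#N)cc6)CC5)CC4)cc3)oc2c1` differs by cyano in place of trifluoromethyl on an aromatic carbon; in this assay compound 2 gives 8470 nM. For the measured compounds named here, this step, an at least 4.7-fold lower number from compound 1 to compound 2 (0.67 log units; beyond the scatter), is the only measured instance of the change. Compound 3 `CCN(CC)c1ccc2cc(C(=O)c3ccc(N4CCN(C(=O)CN5CCN(Cc6ccc(C(F)(F)F)cc6)CC5)CC4)cc3)oc2c1` replaces the sulfonyl link with a benzyl link, and in this assay compound 3 gives only a limit, > 40000 nM. The step of an at least 4.7-fold higher number from compound 2 to compound 3 (0.67 log units; beyond the scatter) is therefore bounded rather than numbered. The difference between the cores of compound 1 and compound 3 is not broken down here.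

Going by the values given here, compound 4 `CCN(CC)c1ccc2cc(C(=O)c3ccc(N4CCN(C(=O)CN5CCN(Cc6ccc(C#N)cc6)CC5)CC4)cc3)oc2c1` is yet to be measured; it differs from compound 3 by cyano in place of trifluoromethyl on an aromatic carbon, the same change as the one from compound 1 to compound 2, at a place described in the same words. On these data alone, the expected step is an at least 2.0-fold lower number from compound 3 to compound 4 (0.30 log units; that floor lies within the scatter), set beside an at least 4.7-fold lower number from compound 1 to compound 2 (0.67 log units; beyond the scatter); since compound 3 sits at the limit of > 40000 nM in this assay, at which 2 of the 3 values shown sit, the starting point is unknown and the expectation is loose. Compound 4 is estimated at 20000 nM, between 6000 nM and 60000 nM in this assay.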

Compound 4, half-maximal inhibitory concentration: > 40000 nM
Compound 4 gave a limit, no number; the forecaster's own chance of this, stated with the estimate: 40%; middle value at least 2.0-fold (0.30 log units) from the limit.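

In this assay compound 4 gives > 40000 nM, which is a limit and not a number. For the compounds shown here, compound 3 is held at a limit too, so the step for cyano in place of trifluoromethyl cannot be read on the benzyl-linked core, and the data neither confirm nor exclude that the change carries over from the sulfonyl-linked core: the limit of > 40000 nM in this assay, at which 3 of the 4 values shown sit. The one readable new step is an at least 4.7-fold higher number from compound 2 to compound 4 (0.67 log units; beyond the scatter), with 4-cyanobenzyl in place of (4-cyanophenyl)sulfonyl on an amine nitrogen in a ring; a readable cyano step therefore stands only on the sulfonyl-linked core, and it rests on a single pair.

On these data alone, it remains open whether an amine or a carboxylic acid in place of the cyano, or a longer chain in place of the benzyl link, would bring the benzyl-linked core to a measurable number. Also open, as far as these compounds go, is how an amine on the sulfonyl-linked core would compare with compound 2 at 8470 nM.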